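Adding a methoxycarbonyl to the oxazoline ring

A few compounds are considered here, and "the series" means these few. Any claim that something is new, unique, unknown or untested is made for them only; others in the source may bear on it.

Three carbamates built on the same core have been measured in an assay (strain Wistar) for inhibition of Fatty-acid amide hydrolase 1 (Rattus norvegicus), read by scintillation counting; a lower number here means a stronger inhibitor, a higher number a weaker inhibitor. Compound 1 `O=C(NC1CCCC1)Oc1cccc(C2=NCCO2)c1` gives 13 nM. Compound 2 `O=C(NC1CCCCC1)Oc1cccc(C2=NCCO2)c1` gives 1.2 nM. Compound 3 `CC1(C)COC(c2cccc(OC(=O)NC3CCCCC3)c2)=N1` gives 46 nM. Compound 2 thus has the lowest number of the three: the step of an 11-fold lower number from compound 1 to compound 2 (1.03 log units; beyond the scatter) moved it well clear of compound 1, and the step of a 38-fold higher number from compound 2 to compound 3 (1.58 log units; beyond the scatter) set it still further apart from compound 3.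

Compound 4 `COC(=O)[C@@H]1COC(c2cccc(OC(=O)NC3CCCCC3)c2)=N1` is compound 2 with one change: methoxycarbonyl in place of hydrogen on a saturated ring carbon. For the measured compounds named here, of the two measured steps, only the one from compound 2 to compound 3 touches the same five-membered ring, and there two methyl groups on a saturated ring carbon gave the large step of a 38-fold higher number from compound 2 to compound 3 (1.58 log units; beyond the scatter). The step from compound 1 to compound 2 concerns the other end of the molecule and says nothing about this ring. Going by the values given here, with a single, larger group now placed on a saturated ring carbon of that ring, a weaker result than compound 2 is expected, though the size of the loss is uncertain, since only one such step is known. For compound 4 in this assay the estimate is 15 nM, within a range of 3 nM to 80 nM, which means an expected step of a 13-fold higher number from compound 2 to compound 4 (1.10 log units; beyond the scatter).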

Compound 4, half-maximal inhibitory concentration: 9.4 nM
Beside the measured number, compound 4's estimate is 1.6-fold (0.20 log units) above it; the range from low to high includes it.
By their numbers in this assay, from the lowest: compound 2; then compounds 4 and 1 (each within the scatter of the next); then compound 3.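

With a 7.8-fold higher number from compound 2 to compound 4 (0.89 log units; beyond the scatter), a methoxycarbonyl on this ring carbon still leaves compound 4 weaker than compound 2, so in this small set the unsubstituted ring carbon gives the lowest number. Even so, the earlier drop seen with two methyl groups is not a fixed price for substituting here: in this assay compound 4 gives 9.4 nM and compound 3 gives 46 nM, which shows that what enters on the saturated ring carbon next to the ring nitrogen matters, not only that something enters. Nothing measured here explains why these two changes differ in size.

Compound 3 and compound 4 differ both in the kind of group and in how many groups sit on this carbon, so the two influences cannot be pulled apart; a single methyl, a hydroxymethyl or a carboxylic acid at the same place would help separate them. Also open, on these data alone, are the mirror-image form of compound 4 and whether the methoxycarbonyl step keeps its size when the cyclopentyl of compound 1 stands in place of cyclohexyl.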